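From Benzyloxy to 4-Bromophenyl on a Carbonyl Carbon

The compounds below may be only part of what the source reports. "The series", "measured", "known", "first", "only" and "open" are said of these compounds alone.

In a functional assay on OCI-Ly3 cells (Homo sapiens) for inhibition, read by CellTiter-Glo, with stated times of 48 h and 96 h (a lower number here means a stronger inhibitor of growth, a higher number a weaker inhibitor of growth), compound 1 (`CC(C)[C@H](NC(=O)c1ccc(Br)cc1)C(=O)N1CCC[C@H]1C(=O)N[C@@H](CCCNC(=N)N)C(=O)CF`) gives 130 nM and compound 2 (`CC(C)[C@H](NC(=O)OCc1ccccc1)C(=O)N1C[C@H](O)C[C@H]1C(=O)N[C@@H](CCCNC(=N)N)C(=O)CF`) gives 290 nM (the higher of the two values, with a gap beyond the scatter). Compound 3 (`CC(C)[C@H](NC(=O)c1ccc(Br)cc1)C(=O)N1C[C@H](O)C[C@H]1C(=O)N[C@@H](CCCNC(=N)N)C(=O)CF`) differs from compound 2 by having 4-bromophenyl in place of benzyloxy on a carbonyl carbon. For the measured compounds named here, no measured pair shows this change alone. Compound 1 also carries 4-bromophenyl and stands at 130 nM in this assay so a small move toward a lower number is expected. The expected change is a 1.7-fold lower number from compound 2 to compound 3 (0.23 log units; within the scatter) and it may stay within the scatter. Compound 3 is estimated at 170 nM (expected range 70 nM to 400 nM).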

Compound 3, concentration for 50% growth inhibition: 70 nM
Beside the measured number, compound 3's estimate is 2.4-fold (0.39 log units) above it, and the stated range covers the measured number.
By their numbers in this assay, from the lowest: compounds 3 and 1 (each within the scatter of the next); then compound 2.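

In this assay, putting 4-bromophenyl in place of benzyloxy on a carbonyl carbon, with the hydroxy group kept on the saturated ring carbon, gives a 4.1-fold lower number from compound 2 to compound 3 (0.62 log units; beyond the scatter), so this change alone moves the number beyond the scatter. Hydroxy in place of hydrogen on a saturated ring carbon gives a 1.9-fold lower number from compound 1 to compound 3 (0.27 log units; within the scatter), which stays within the scatter and shows no clear effect of that group. Nothing at hand bears on the cause of either step. The compounds shown leave open how an amine or a carboxylic acid in place of 4-bromophenyl on that carbonyl carbon would read in this assay.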